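The source may hold more compounds than are shown below. What is called first, only, known or untested is meant among the compounds shown, and "the series" means these compounds.

In a physicochemical assay for acid dissociation, compound 1 `Brc1ccc(N(CC2CC2)C2=NCCN2)c(Br)c1` gives 11.2 and compound 2 `CC(C)N(C1=NCCN1)c1c(Br)cccc1Br` gives 11.2 while compound 3 `C=C(C)CN(C1=NCCN1)c1c(Br)cccc1Br` gives 10.7 as the lowest of the three numbers. Compound 4 `Brc1cccc(Br)c1N(CC1CCCCC1)C1=NCCN1` has not been measured yet. It keeps the core of compound 3 and changes one group on a saturated chain carbon bound to a nitrogen on an aromatic ring, where cyclohexyl stands in place of 1-methylethenyl (cyclohexyl in place of 1-methylethenyl on a saturated chain carbon bound to a nitrogen on an aromatic ring). Read one bond further out, 2-methylprop-2-en-1-yl gives way to cyclohexylmethyl. For the measured compounds named here, only one measured step touches this group: the modest change (a number 0.50 log units lower from compound 2 to compound 3 (beyond the scatter)) came with 2-methylprop-2-en-1-yl in place of isopropyl. Going by the values given here, compound 4 gives that group up again, although no measurement yet shows what cyclohexylmethyl itself does. A modest move upward in this assay is therefore expected, toward the number of compound 2 (11.2) but not past it. The expected size of this move is a number 0.40 log units higher from compound 3 to compound 4 (beyond the scatter) for now. For compound 4 the estimate is 11.1 with an expected range from 10.7 to 11.5 as its limits.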

Compound 4, acid dissociation constant: 11.2
The estimate for compound 4 lay 0.10 log units below the measured number; measured number inside the range.
By their numbers in this assay, from the lowest: compound 3; then compounds 1, 2 and 4 (each within the scatter of the next).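

In this assay, for the compounds shown here, cyclohexyl in place of 1-methylethenyl on a saturated chain carbon bound to a nitrogen on an aromatic ring gives a number 0.50 log units higher from compound 3 to compound 4 (beyond the scatter) and thus a first reading for cyclohexylmethyl itself. The larger cyclohexylmethyl and the smaller isopropyl read alike, with no change at the digits printed from compound 2 to compound 4 (within the scatter) and so, among compound 2, compound 3 and compound 4, only compound 3, whose group holds a double bond outside aromatic rings, stands apart. Nothing shown here explains why the numbers fall this way.

With only these groups, the double bond cannot be separated from the other differences in the group. On these data alone, a 2-methylpropyl group, the same chain without its double bond, would isolate that feature, while a chain ending in an amine or a carboxylic acid remains unexplored at this position.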